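The compounds below may be only part of what the source reports. "The series", "measured", "known", "first", "only" and "open" are said of these compounds alone.

In an ADME assay on L132 cells (Homo sapiens) for cytotoxicity, read by MTT assay, with a stated time of 72 h (on this read-out higher numbers stand for weaker inhibition and lower numbers for stronger inhibition), compound 1 `COc1ccc(C2=C(c3cc(OC)c(OC)c(OC)c3)C(=O)CC2O[SiH2]C(C)(C)C)cc1` stands at > 100 ug/mL as a limit only. Within the data shown here, compound 2 `COc1ccc(OC)c(C2=C(c3cc(OC)c(OC)c(OC)c3)C(=O)CC2O[SiH2]C(C)(C)C)c1` gives 100 ug/mL as the only actual number so far. Compound 3 `COC(=O)c1cc(C2=C(c3cc(OC)c(OC)c(OC)c3)C(=O)CC2O[SiH2]C(C)(C)C)ccc1OC` differs from compound 2 by 4-methoxy-3-(methoxycarbonyl)phenyl in place of 2,5-dimethoxyphenyl on a double-bonded ring carbon with 4-methoxy-3-(methoxycarbonyl)phenyl in place of 2,5-dimethoxyphenyl on a double-bonded ring carbon. Among the measured compounds shown here, the one measured step of a number no higher from compound 1 to compound 2 (the limit leaves the size open) is the only guide here, but it has no readable size because of the limit of > 100 ug/mL in this assay, at which 1 of the 2 values shown sits, and so sets no direction. The expected step of no change at the digits printed from compound 2 to compound 3 (within the scatter) in this assay therefore stays within the scatter. For compound 3 the estimated value is 100 ug/mL with an expected range from 45 ug/mL to 200 ug/mL in this measurement.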

Compound 3, half-maximal inhibitory concentration: > 100 ug/mL
Compound 3: a limit, no number; the forecaster's own chance of this, stated with the estimate: 45%; the middle value lies on the limit itself.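

In this assay, 4-methoxy-3-(methoxycarbonyl)phenyl on the double-bonded ring carbon gives a number no lower from compound 2 to compound 3 (the limit leaves the size open), so this change brings no stronger inhibition. Compound 3 gives > 100 ug/mL, which is a limit and not a number. The sizes of the steps to compound 3 cannot be read because of a limit: the limit of > 100 ug/mL in this assay, at which 2 of the 3 values shown sit.

On these data alone, whether an amine or a carboxylic acid in place of the methoxycarbonyl would give stronger inhibition remains open. As far as these compounds go, how far compound 1 and compound 3 lie from each other also stays open.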